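The source may report more compounds than this note shows. Statements on the series, on what has been measured and on what is new or still open speak of the compounds shown alone.

Measured so far:
compound 1 `CCC(=O)Nc1sc2c(c1C#N)CCCC2`: 12000 nM
compound 2 `CC(C)c1cc(C(C)(C)C)cc(-c2cccc(C(F)(F)F)c2)c1CO`: > 50000 nM
compound 3 `CC(C)c1cc(C(C)(C)C)cc(-c2ccc(Cl)cc2)c1CO`: 290 nM

In a functional assay on RKE cells for antagonist activity at Vasoactive intestinal polypeptide receptor 1 (Rattus norvegicus), read by HTRF and cAMP accumulation, with stated times of 10 min and 30 min (a lower number here means a stronger inhibitor, a higher number a weaker inhibitor), compound 2 gives only a limit, > 50000 nM, not a number; it sits at the limit of > 50000 nM in this assay, at which 1 of the 3 values shown sits. Compound 3 gives 290 nM, and compound 1 gives 12000 nM. Compound 4 `CC(C)c1cc(C(C)(C)C)cc(-c2cccc(-c3ccccc3)c2)c1CO` is not yet measured. It differs from compound 2 by phenyl in place of trifluoromethyl on an aromatic carbon, meta to a large group. Within the data shown here, no measured pair shows this exact change, so the size of the step is uncertain; the step from compound 2 to compound 4 is expected to be an at least 3.3-fold lower number from compound 2 to compound 4 (0.52 log units; beyond the scatter), toward a stronger inhibitor but with a real chance that only a limit is returned again. Compound 4 is expected to give about 15000 nM, estimated between 2000 nM and 50000 nM.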

Compound 4, half-maximal inhibitory concentration: 210 nM
For compound 4 the middle estimate is 71-fold (1.85 log units) above the measured one; the measured number lies below the stated range.
By their numbers in this assay, from the lowest: compounds 4 and 3 (each within the scatter of the next); then compound 1. At a limit, above all of these: compound 2.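

Putting phenyl in place of trifluoromethyl on this aromatic carbon, meta to a large group, gives an at least 230-fold lower number from compound 2 to compound 4 (2.37 log units; beyond the scatter). What sits at this position can therefore decide between strong inhibition and none detected, and a second aromatic ring here is compatible with strong inhibition. Compound 2 stands at a limit, not a number: the limit of > 50000 nM in this assay, at which 1 of the 4 values shown sits.

On these data alone, whether the gain comes from adding phenyl or from losing trifluoromethyl stays open. As far as these compounds go, how an amine, a carboxylic acid or a methoxy group would behave at this position also remains unknown.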